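1H-pyrrol-2-yl replaces methylcarbamoyl: expected cytotoxicity

The source may report more compounds than this note shows. Statements on the series, on what has been measured and on what is new or still open speak of the compounds shown alone.

Compound 2 `CNC(=O)c1ccc(NCc2cncn2Cc2ccc(-c3ccccc3)cc2)cc1-c1ccccc1` has been tested in a toxicity assay on NIH3T3 cells (Mus musculus) for cytotoxicity, read by resazurin assay; on this read-out lower numbers stand for an effect already at smaller amounts and higher numbers for an effect only at larger amounts of compound. In this assay compound 2 gives > 1000 nM, which is a limit of the assay and not a number. Compound 1 `CNC(=O)c1ccc(NCc2cncn2Cc2ccc(-c3ccccc3)cc2N)cc1-c1ccccc1` carries an amino on an aromatic carbon where compound 2 has hydrogen. In this assay compound 1 gives > 1000 nM, again a limit. The step that the two limits leave unreadable from compound 1 to compound 2 is therefore unreadable, as the limit of > 1000 nM in this assay, at which 3 of the 3 values shown sit, shows. Compound 3 `Cc1cccc(-c2cc(NCc3cncn3Cc3ccc(-c4ccccc4)cc3)ccc2-c2nc3ccccc3s2)c1C` belongs to the same series. In this assay compound 3 gives > 1000 nM, also a limit. Compound 4 `c1ccc(-c2ccc(Cn3cncc3CNc3ccc(-c4ccc[nH]4)c(-c4ccccc4)c3)cc2)cc1` has not been measured. It differs from compound 2 by 1H-pyrrol-2-yl in place of methylcarbamoyl on an aromatic carbon. Going by the values given here, no measured step bears directly on this exchange; the single recorded step is unreadable, and every value so far sits at the limit. The expected step is a step that the limit leaves unreadable from compound 2 to compound 4, nothing beyond the scatter and most likely another limit. Compound 4 is therefore expected to give 3000 nM in this assay, estimated to lie between 1000 nM and 10000 nM.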

Compound 4, half-maximal effective concentration: > 10000 nM
Compound 4: no number, only a limit; the forecaster's own chance of this, stated with the estimate: 80%; middle value at least 3.3-fold (0.52 log units) away from the limit.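

Compound 2 and compound 4 both give limits and not numbers, so the step between them cannot be read. The compounds shown leave open at what concentration any of them acts, and whether 1H-pyrrol-2-yl in place of methylcarbamoyl changes that at all.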